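Dithiocarbonate aryl ketones: sulfamoyl to isocyanide swap

The source may report more compounds than this note shows. Statements on the series, on what has been measured and on what is new or still open speak of the compounds shown alone.

Working notes on a small set of aryl ketones carrying a trithiocarbonate side chain. Compound 1 `CCSC(=S)SCC(=O)c1ccc(S(N)(=O)=O)cc1` and compound 2 `CCSC(=S)SCC(=O)c1ccc(OC)cc1OC` share this core and differ only in the substitution of the aromatic ring. In a functional assay on HeLa cells (Homo sapiens) for antiproliferative activity, read by resazurin assay (a lower number here means a stronger inhibitor, a higher number a weaker inhibitor), compound 1 gives 20000 nM. In this assay compound 2 gives 12600 nM. Compound 1 therefore stands at the highest of the two numbers, but its gap to compound 2 lies within the usual scatter, so the two values are best read as equivalent. Both compounds are weak in this assay.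

Compound 3 `[C-]#[N+]c1ccc(C(=O)CSC(=S)SCC)cc1` has not yet been measured in this assay. It differs from compound 1 in one place: a group of 2 heavy atoms (1 carbon, 1 nitrogen; no ring) in place of a group of 4 heavy atoms (1 nitrogen, 2 oxygen, 1 sulfur; no ring), on an aromatic carbon. Among the measured compounds shown here, no step between measured compounds covers this kind of change, and the one pair of numbers in hand gives no direction. The step from compound 1 to compound 3 is expected to be small, a 1.3-fold lower number from compound 1 to compound 3 (0.12 log units; within the scatter), with no direction beyond the scatter. For compound 3 the expected value in this assay is 15000 nM, with a range from 5000 nM to 50000 nM.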

Compound 3, half-maximal inhibitory concentration: 7940 nM
Compound 3: the middle estimate sits 1.9-fold (0.28 log units) above what was measured; measured number inside the range.
By their numbers in this assay, from the lowest: compounds 3, 2 and 1 (each within the scatter of the next, the first and the last beyond it).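

In this assay, the aromatic carbon that carries sulfamoyl in compound 1 now gives a first readable single-place step: replacing sulfamoyl with the group of 2 heavy atoms gives a 2.5-fold lower number from compound 1 to compound 3 (0.40 log units; beyond the scatter), a modest change that still leaves compound 3 at 7940 nM in the same assay. The entering group has 0 hydrogen-bond donors and 0 hydrogen-bond acceptors, whereas sulfamoyl has 1 and 2, so these sulfamoyl features are not required for compound 3 to reach this number. Nothing on hand explains the step.

Still open, as far as these compounds go, is whether the lower number is specific to the entering group, or whether a nitrile, a methyl group or an amine on the same aromatic carbon would give a similar result. Also open, from the compounds shown here alone, is how the number responds to changes elsewhere, such as a longer chain on the trithiocarbonate side or a carboxylic acid at the end of that side chain, with the aromatic substitution of compound 3 held constant.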